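Ester and amide analogues of a shared pyrazole core

The source may report more compounds than this note shows. Statements on the series, on what has been measured and on what is new or still open speak of the compounds shown alone.

Measured compounds:
- compound 1 `CC(C)c1cccc(OC(=O)c2cn(-c3ccccc3)nc2-c2cccnc2)c1`: 75500 nM
- compound 2 `O=C(c1cn(-c2ccccc2)nc1-c1ccncc1)N1CCC(Cc2ccccc2)CC1`: 56400 nM
- compound 3 `CC(C)c1cccc(OC(=O)c2cn(-c3ccccc3)nc2-c2ccncc2)c1`: "nd(insoluble)" (no result reported)

In a functional assay on MCF7 cells (Homo sapiens) for cytotoxicity, read by MTT assay, with a stated time of 48 h (a higher number here means a weaker inhibitor, a lower number a stronger inhibitor), compound 1 gives 75500 nM and compound 2 gives 56400 nM; the two values lie within the usual scatter of each other, so neither can be called the stronger. Compound 3 differs from compound 1 only in the pyridine attachment and was not assigned a number in this assay, where compound 3 is recorded as "nd(insoluble)" (no result reported). Compound 3 therefore stands nowhere on the scale; it supplies no starting value.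

Compound 4 `O=C(Oc1ccc2ccccc2c1)c1cn(-c2ccccc2)nc1-c1ccncc1` is built from compound 3 by the change (naphthalen-2-yl in place of 3-isopropylphenyl on an oxygen next to a carbonyl group). Among the compounds with values here, no measured pair shows this step, so the direction is open. The two esters and the amide that do carry numbers both sit at weak, high-concentration values, and nothing in the measured set points toward a large move away from that region. The size of the step from compound 3 is expected to be small, in either direction, or none beyond the scatter. Compound 4 is expected to reach about 55000 nM in this assay, with a plausible range from 15000 nM to 150000 nM.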

Compound 4, half-maximal inhibitory concentration: 44500 nM
For compound 4 the middle estimate is 1.2-fold (0.09 log units) above the measured one; measured number inside the range.
By their numbers in this assay, from the lowest: compounds 4, 2 and 1 (each within the scatter of the next).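

In this assay, within the data shown here, compound 4 gives 44500 nM while compound 3 is recorded as "nd(insoluble)" (no result reported) and carries no number, so no step between compound 3 and compound 4 can be read. Going by these compounds, what naphthalen-2-yl does in place of 3-isopropylphenyl, on an oxygen next to a carbonyl group, stays open. No evidence shown here bears on these results.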